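Tert-butyl in place of trifluoromethyl: notes on compound 3

This account rests on a few compounds, and the source may have more. Where it says the series, first, only, none or still open, it means among the compounds named here.

Of the compounds shown here, two have numbers so far. Compound 1 `O=C(Nc1ccc(-c2ccccn2)cc1)c1ccc(C(F)(F)F)cc1` is an amide; in a functional assay on CHO cells for antagonist activity at transient receptor potential cation channel subfamily V member 1 (Homo sapiens), read by FLIPR (on this read-out lower numbers stand for stronger inhibition and higher numbers for weaker inhibition), compound 1 gives 1500 nM. Compound 2 `FC(F)(F)c1ccc(-c2nc3cc(-c4ncccc4C(F)(F)F)ccc3[nH]2)cc1` carries a different core bearing a pyridine with a trifluoromethyl group; in this assay compound 2 gives 22 nM, the lowest of the two numbers, and its gap to compound 1 lies well beyond the scatter. The two structures differ in many places at once, so nothing can be said about which part of the change carries the gain.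

Compound 3 `CC(C)(C)c1ccc(-c2nc3cc(-c4ncccc4C(F)(F)F)ccc3[nH]2)cc1` is not yet measured. It differs from compound 2 in one place: tert-butyl in place of trifluoromethyl on an aromatic carbon. Among the compounds with values here, no pair of measured compounds shows this change, so the size of the step is not known from the data. The two groups are of the same heavy-atom count, neither brings a donor, an acceptor or a charge, and the rest of the structure is unchanged, so the step in this assay from compound 2 to compound 3 is expected to be small, within or near the scatter, with no direction favoured; the estimated step is a 1.4-fold higher number from compound 2 to compound 3 (0.13 log units; within the scatter). For compound 3 the expected value in this assay is 30 nM, with a range from 8 nM to 120 nM.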

Compound 3, half-maximal inhibitory concentration: 224 nM
Beside the measured number, compound 3's estimate is 7.5-fold (0.87 log units) below it; the whole stated range lies below it.
By their numbers in this assay, from the lowest: compound 2; then compound 3; then compound 1.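

In this assay, tert-butyl in place of trifluoromethyl gives a 10-fold higher number from compound 2 to compound 3 (1.01 log units; beyond the scatter) and so marks this position, on an aromatic carbon of a six-membered aromatic ring of carbon only and para to a large group, as sensitive to the group it carries. That sensitivity appears even though the two groups match in heavy-atom count and neither brings a hydrogen-bond donor, a hydrogen-bond acceptor or a net charge. The earlier pair differed in many places and could assign its gap to no single part, whereas this step belongs to one change alone, and nothing in hand explains why the two groups differ so much.

Still open, on these data alone, is how other groups at this position would compare: a single exchange cannot say whether chlorine, a methoxy group or a nitrile would read close to compound 2 or close to compound 3. Also open, as far as these compounds go, is whether the same exchange at the other trifluoromethyl group, the one on the pyridine, would give a step of similar size.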